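Aryl substituent variation: step to the nitro analogue

The compounds below may be only part of what the source reports. "The series", "measured", "known", "first", "only" and "open" are said of these compounds alone.

Measured compounds and minimum effective doses:
compound 1 `O=C(/N=C/c1ccc(Cl)cc1)Nc1ccc2c(c1)C(=O)C(=O)N2CN1CCCCC1`: 100 mg/kg
compound 2 `O=C(/N=C/c1ccccc1Cl)Nc1ccc2c(c1)C(=O)C(=O)N2CN1CCCCC1`: 100 mg/kg
compound 3 `O=C(/N=C/c1ccc(F)cc1)Nc1ccc2c(c1)C(=O)C(=O)N2CN1CCCCC1`: 100 mg/kg

All three were tested in a functional assay on the whole organism (strain Swiss albino) with Mus musculus as the target, with a stated time of 0.5 h; a higher number here means that more compound is needed for the effect, a lower number that less compound is needed. Compound 1 gives 100 mg/kg there, compound 2 gives 100 mg/kg and compound 3 gives 100 mg/kg. The three single-point changes among them are all flat: no change at the digits printed from compound 1 to compound 2 (within the scatter); no change at the digits printed from compound 1 to compound 3 (within the scatter); no change at the digits printed from compound 2 to compound 3 (within the scatter). Compound 3 therefore stands level with compounds 1 and 2 at the digits shown, neither the strongest nor the weakest of the set.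

The next compound, compound 4 `O=C(/N=C/c1ccc([N+](=O)[O-])cc1)Nc1ccc2c(c1)C(=O)C(=O)N2CN1CCCCC1`, differs from compound 3 in one place: nitro in place of fluoro on an aromatic carbon.

Which measured steps bear on this? Only indirectly. The steps from compound 1 to compound 2 and from compound 1 to compound 3 show that moving a halogen around the ring and exchanging one halogen for another leave the dose unchanged within the scatter. Within the data shown here, no measured step introduces a nitro group, so its effect is not covered by the data. Given that every substituent change so far has been flat in this assay, the expectation for compound 4 is no step beyond the scatter, no change at the digits printed from compound 3 to compound 4 (within the scatter). Compound 4 is thus estimated at 100 mg/kg, with a range from 50 mg/kg to 200 mg/kg.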

Compound 4, minimum effective dose: 30 mg/kg
Compound 4: the middle estimate sits 3.3-fold (0.52 log units) above what was measured; measured number below the stated range.
By their numbers in this assay, from the lowest: compound 4; then compounds 1, 2 and 3 (each within the scatter of the next).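

In this assay the aromatic ring is not a silent position: nitro in place of fluoro gives a 3.3-fold lower number from compound 3 to compound 4 (0.52 log units; beyond the scatter) and nitro in place of chloro gives a 3.3-fold lower number from compound 1 to compound 4 (0.52 log units; beyond the scatter) while the 4-nitrophenyl in place of the 2-chlorophenyl gives a 3.3-fold lower number from compound 2 to compound 4 (0.52 log units; beyond the scatter) as well. The earlier flat steps therefore describe only the halogen exchanges and the move of chloro among compounds 1, 2 and 3, not a ring that tolerates every substituent without a change in dose. All three steps end at compound 4 and share one entering group, so they show a single nitro result against three level halogen compounds, and no measurement shown explains it.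

Still open, going by these compounds, is whether this step belongs to the nitro group alone or also appears with a nitrile, a trifluoromethyl, a methoxy or an amine on the same aromatic carbon. Also open, on these data alone, is whether nitro keeps the step when it stands where the chloro of compound 2 stands, which would show how far the result depends on the place as well as on the group.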